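Nitrophenyl methanesulfonamides: alkoxy and sulfonamide nitrogen changes

A few compounds are considered here, and "the series" means these few. Any claim that something is new, unique, unknown or untested is made for them only; others in the source may bear on it.

Measured so far:
compound 1 `CS(=O)(=O)Nc1ccc([N+](=O)[O-])cc1OC1CCCC1` — 870 nM
compound 2 `CCC(CC)Oc1cc([N+](=O)[O-])ccc1NS(C)(=O)=O` — 300 nM

Two compounds of this series have numbers in an assay on SK-BR-3 cells for inhibition of Aromatase (Homo sapiens); a higher number here means a weaker inhibitor, a lower number a stronger inhibitor. Compound 1 `CS(=O)(=O)Nc1ccc([N+](=O)[O-])cc1OC1CCCC1` gives 870 nM; compound 2 `CCC(CC)Oc1cc([N+](=O)[O-])ccc1NS(C)(=O)=O` gives 300 nM. Among the compounds with values here, the one step between them, a 2.9-fold lower number from compound 1 to compound 2 (0.46 log units; beyond the scatter), puts compound 2 at the lower of the two numbers, and the gap to compound 1 lies beyond the scatter. Nothing else in the set is known.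

Compound 3 `CCC(CC)Oc1cc([N+](=O)[O-])ccc1N(C)S(C)(=O)=O` is the next candidate and has not been measured in this assay. It differs from compound 2 in one place: methyl in place of hydrogen on a sulfonamide nitrogen. Within the data shown here, the alkoxy group of compound 2, which carried the only measured step, is kept.

Among the measured compounds shown here, no measured step touches the sulfonamide nitrogen, so the step from compound 1 to compound 2 says nothing about this change; it only fixes the starting point at compound 2. Absent any bearing step, the expectation for compound 3 is a step of no clear direction, a 1.2-fold higher number from compound 2 to compound 3 (0.07 log units; within the scatter), within the scatter about compound 2 but with a wide margin. Compound 3 is therefore estimated at 350 nM in this assay, in the range 120 nM to 1100 nM.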

Compound 3, half-maximal inhibitory concentration: 230 nM
Compound 3: the middle estimate sits 1.5-fold (0.18 log units) above what was measured; low and high end bracket the measured number.
By their numbers in this assay, from the lowest: compounds 3 and 2 (each within the scatter of the next); then compound 1.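

In this assay, within the data shown here, the change of methyl in place of hydrogen on the sulfonamide nitrogen gives a 1.3-fold lower number from compound 2 to compound 3 (0.12 log units; within the scatter) and so opens a position that the earlier compounds left untouched. Among these compounds, with pentan-3-yl kept on the oxygen, the sulfonamide hydrogen of compound 2 can be replaced by methyl with no difference that can be told from the scatter, whereas the alkoxy change remains the only step here that lies beyond it, at a 2.9-fold lower number from compound 1 to compound 2 (0.46 log units; beyond the scatter) in the same assay. Nothing available accounts for how the sulfonamide nitrogen takes this methyl group.

The compounds shown leave open how an ethyl group, a longer chain or an acetyl group on the sulfonamide nitrogen would read in this assay and so how far this position can be changed beyond a single methyl. They also leave open whether methyl on that nitrogen reads the same with cyclopentyl on the oxygen, as in compound 1, since the nitrogen change is seen with pentan-3-yl alone.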